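The source may hold more compounds than are shown below. What is called first, only, known or untested is meant among the compounds shown, and "the series" means these compounds.

Measured in a functional assay on VCaP cells (Homo sapiens) for antiproliferative activity, read by CCK-8 assay, with a stated time of 6 days; a higher number here means a weaker inhibitor, a lower number a stronger inhibitor:
Compound 1 `CCN(c1ccc(C#N)c(Cl)c1)c1cc(-c2cncnc2)ccc1C`: 3920 nM
Compound 2 `CCN(c1ccc(C#N)c(Cl)c1)c1cc(-c2ccnn2C)ccc1C`: 1670 nM

Compound 2 holds the lower of the two numbers. Compound 3 `CCN(c1ccc(C#N)c(Cl)c1)c1cc(-c2ccc(F)nc2)ccc1C` departs from it at one place: 6-fluoropyridin-3-yl in place of 1-methyl-1H-pyrazol-5-yl on an aromatic carbon. Going by the values given here, only one measured step bears on this change, a modest one at the same place: a 2.3-fold lower number from compound 1 to compound 2 (0.37 log units; beyond the scatter). Among the compounds with values here, the 6-fluoropyridin-3-yl group brings back a six-membered aromatic ring, as in compound 1 at 3920 nM, so a small rise in the number is expected, probably no larger than that step. The expected change is a 1.3-fold higher number from compound 2 to compound 3 (0.12 log units; within the scatter). The estimate for compound 3 is 2200 nM, with an expected range from 700 nM to 6500 nM.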

Compound 3, half-maximal inhibitory concentration: > 30000 nM
Compound 3: no number, only a limit; the forecaster's own chance of this, stated with the estimate: 3%; at least 13-fold (1.13 log units) between middle value and limit.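

In this assay, this position, on the ring para to a methyl group, proves far more sensitive than the first pair suggested: 6-fluoropyridin-3-yl gives an at least 17-fold higher number from compound 2 to compound 3 (1.25 log units; beyond the scatter), and against pyrimidin-5-yl it gives an at least 7.6-fold higher number from compound 1 to compound 3 (0.88 log units; beyond the scatter). A six-membered aromatic ring alone does not set this outcome, since compound 1 also carries one and gives 3920 nM. The reading for compound 3 is a limit of the assay, not a number: the limit of > 30000 nM in this assay, at which 1 of the 3 values shown sits.

From the compounds shown here alone, it remains open whether the fluorine accounts for this loss, and how a plain pyridin-3-yl or a ring carrying an amine would read in this assay.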